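This account rests on a few compounds, and the source may have more. Where it says the series, first, only, none or still open, it means among the compounds named here.

Working notes on the series. Two compounds carry measurements in an assay on Sf21 cells for inhibition of cytochrome c oxidase subunit 2 (Homo sapiens), read by spectrophotometry, with a stated time of 5 min; on this read-out higher numbers stand for weaker inhibition and lower numbers for stronger inhibition. Compound 1 `COc1ccc(C(=O)CC2CC(=O)N(c3ccc(S(N)(=O)=O)cc3)C2=O)cc1` gives 2100 nM in this assay, the lowest of the two numbers recorded. Compound 2 `NS(=O)(=O)c1ccc(N2C(=O)CC(C3CCCCCC3=O)C2=O)cc1` gives 20700 nM in this assay, a weaker result than compound 1 by a margin that lies beyond the scatter of repeated measurements. Among the measured compounds shown here, compound 2 differs from compound 1 in more than one place, so no single step between them is drawn here; only the two values themselves are set side by side.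

The next compound to be measured is compound 3 `Cc1ccc(C(=O)CC2CC(=O)N(c3ccc(S(N)(=O)=O)cc3)C2=O)cc1`, which differs from compound 1 in a single place: methyl in place of methoxy on an aromatic carbon. For the measured compounds named here, for this change no measured step exists anywhere, so its size can only be anticipated. The step from compound 1 to compound 3 in this assay, a 1.5-fold higher number from compound 1 to compound 3 (0.18 log units; within the scatter), is expected to be modest, most likely a small loss of potency, with a result within the scatter of compound 1 quite possible. Compound 3 is therefore estimated at 3200 nM in this assay, with a range from 1000 nM to 10000 nM.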

Compound 3, half-maximal inhibitory concentration: 980 nM
Compound 3: the middle estimate sits 3.3-fold (0.51 log units) above what was measured; the measured number lies below the stated range.
By their numbers in this assay, from the lowest: compound 3; then compound 1; then compound 2.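

Among the compounds shown here, on an aromatic carbon para to a large group, the change from 4-methoxyphenyl to 4-methylphenyl gives in this assay the first single-place step, a 2.1-fold lower number from compound 1 to compound 3 (0.33 log units; beyond the scatter), and this step lies beyond the scatter. The number falls with this change, so within this pair the methoxy group and its one hydrogen-bond acceptor are not needed to hold the inhibition seen with compound 1, and a methyl group at this place is tolerated at least as a modest gain. No supporting measurement bears on why the number falls, and the step stands here as an observation only.

From the compounds shown here alone, it remains open whether the gain belongs to methyl itself or simply to the loss of methoxy, a question that a hydrogen, a chlorine atom, an ethyl group or a carboxylic acid at the same place would bear on. Compound 2 differs from both compound 1 and compound 3 in more than one place, so its higher number cannot be assigned to any single part of the structure.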